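Amide substituent change on a pyrrole core toward a carboxylic acid

The source may report more compounds than this note shows. Statements on the series, on what has been measured and on what is new or still open speak of the compounds shown alone.

Compound 1 `CCn1c(C(=O)NCCCN(C)C)ccc1C(CC)(CC)c1ccc(OCCC(O)(CC)CC)c(C)c1` gives 3350 nM in a functional assay on MCF7 cells (Homo sapiens) for antiproliferative activity, read by MTT assay, with a stated time of 48 h; a lower number here means a stronger inhibitor, a higher number a weaker inhibitor.
Compound 2 `CCn1c(C(=O)NCCN)ccc1C(CC)(CC)c1ccc(OCCC(O)(CC)CC)c(C)c1` gives 670 nM in this assay.
Compound 3 `CCC(C)C(NC(=O)c1ccc(C(CC)(CC)c2ccc(OCCC(O)(CC)CC)c(C)c2)n1CC)C(=O)OC` reaches only the assay limit of > 50000 nM in this assay.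

Compound 2 stands lowest of the two numbers given; the nearest is compound 1, with a 5.0-fold lower number from compound 1 to compound 2 (0.70 log units; beyond the scatter). Compound 4 `CCC(C)C(NC(=O)c1ccc(C(CC)(CC)c2ccc(OCCC(O)(CC)CC)c(C)c2)n1CC)C(=O)O` has not been measured. Its change from compound 2 is 1-carboxy-2-methylbutyl in place of 2-aminoethyl on an amide-type nitrogen.

Among the measured compounds shown here, two measured steps bear on this. Both replace the short amine-bearing chain on the amide-type nitrogen with a larger branched group carrying an ester: an at least 74-fold higher number from compound 2 to compound 3 (1.87 log units; beyond the scatter) and an at least 14-fold higher number from compound 1 to compound 3 (1.17 log units; beyond the scatter). Going by these compounds, in each case the new compound sits at the assay limit (the limit of > 50000 nM in this assay, at which 1 of the 3 values shown sits), so the true size of these steps is unknown, only that it is large. Compound 4 carries a closely related branched group with a free acid, so a step of similar kind is expected: a 75-fold higher number from compound 2 to compound 4 (1.87 log units; beyond the scatter). The estimate for compound 4 is 50000 nM, with a range from 8000 nM to 200000 nM, and a real chance that the assay again reports only a limit.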

Compound 4, half-maximal inhibitory concentration: 11300 nM
For compound 4 the middle estimate is 4.4-fold (0.65 log units) above the measured one, and the stated range covers the measured number.
By their numbers in this assay, from the lowest: compound 2; then compound 1; then compound 4. At a limit, above all of these: compound 3.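

Replacing the methyl of the ester with hydrogen has a clear effect of its own in this assay, with an at least 4.4-fold lower number from compound 3 to compound 4 (0.64 log units; beyond the scatter). The value for compound 3 is a limit, not a number: the limit of > 50000 nM in this assay, at which 1 of the 4 values shown sits. Even so, the 1-carboxy-2-methylbutyl group on this amide-type nitrogen gives a weaker result than either amine-bearing chain, with a 17-fold higher number from compound 2 to compound 4 (1.23 log units; beyond the scatter) and a 3.4-fold higher number from compound 1 to compound 4 (0.53 log units; beyond the scatter).

The compounds shown cannot say whether that loss comes from removing the amine, adding the acid, or adding the branch, as all of these changes arrive together. A straight chain ending in a carboxylic acid and a branched chain ending in an amine would separate these possibilities.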